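The compounds below may be only part of what the source reports. "The series", "measured", "known", "first", "only" and "open" are said of these compounds alone.

Working notes on the series. Going by the values given here, compound 1 `Clc1ccc(-c2nnc(-c3cn(-c4ccccc4)nc3-c3ccc(Cl)cc3)o2)cc1` is the only member with a number: in a functional assay on the whole organism for inhibition, with Rattus norvegicus as the target, read by paw edema, with stated times of 1 h and 2 h (a higher number here means that more compound is needed for the effect, a lower number that less compound is needed), compound 1 gives 199 mg/kg. Compound 2 `Clc1ccc(-c2nnc(-c3cn(-c4ccccc4)nc3-c3ccc(Br)cc3)o2)cc1` shares the same core and differs only in the bromo group on one of its outer rings; in this assay compound 2 gives "not determined" (no result reported), so it carries no number and stands nowhere on the scale shown. Among the compounds with values here, no step between measured compounds is therefore available, and nothing within these data shows how a change on that ring moves the read-out of paw edema.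

Compound 3 `O=[N+]([O-])c1ccc(-c2nn(-c3ccccc3)cc2-c2nnc(-c3ccc(Cl)cc3)o2)cc1` is the next member to be measured. It follows from compound 2 by nitro in place of bromo on an aromatic carbon. Within the data shown here, with no measured step to lean on, no direction can be claimed for this change; the working expectation is that compound 3 stays within the usual scatter of the value known for compound 1, in either direction. On that basis, compound 3 is expected to give about 200 mg/kg in this assay, with a range from 80 mg/kg to 500 mg/kg.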

Compound 3, dose for half-maximal effect: 167 mg/kg
The estimate for compound 3 lay 1.2-fold (0.08 log units) above the measured number, within the range that was stated.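

With compound 3 the series has its first readable step at this position, on an aromatic carbon of the six-membered ring and para to a large group: nitro in place of chloro gives a 1.2-fold lower number from compound 1 to compound 3 (0.08 log units; within the scatter) in this assay. On the two measured compounds, this exchange therefore does not separate the read-out of paw edema, and the position holds nitro as well as chloro with the shared core otherwise unchanged; the step from compound 2 to compound 3 cannot be read, as compound 2 has no number. No measurement on hand gives a reason for this result.

Going by these compounds alone, the single step cannot show whether any group at this position would move the read-out beyond the scatter, and the value of bromo there remains unknown. From the compounds shown here alone, an amine or a carboxylic acid in that place, or a change on the chloro-bearing ring or the phenyl group of the core, remains open, so the two values set no trend for the series.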